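Changing the ring-nitrogen substituent on a shared thiophene-urea core

The source may report more compounds than this note shows. Statements on the series, on what has been measured and on what is new or still open speak of the compounds shown alone.

Measured so far:
- compound 1 `CCN1CCc2c(sc(NC(=O)Nc3ccc4ccccc4c3)c2C(N)=O)C1`: 1780 nM
- compound 2 `NC(=O)c1c(NC(=O)Nc2ccc(Cl)cc2)sc2c1CCN(C1CCOCC1)C2`: 2830 nM

Among the compounds with values here, both compounds share the same fused core and differ in two places at once, so no single step between them can be read off. In a functional assay (strain AB) with Danio rerio as the target, read by microscopy, with a stated time of 1 h (on this read-out lower numbers stand for an effect already at smaller amounts and higher numbers for an effect only at larger amounts of compound), compound 1 gives 1780 nM. In this assay compound 2 gives 2830 nM, the higher of the two numbers, although the gap to compound 1 lies within the usual scatter of repeated measurements, so the two are best treated as alike.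

Compound 3 `CC(C)(C)OC(=O)CCCN1CCc2c(sc(NC(=O)Nc3ccc(Cl)cc3)c2C(N)=O)C1` keeps the core and the chloro-substituted urea of compound 2 and alters only one place: 3-(tert-butoxycarbonyl)propyl in place of oxan-4-yl on an amine nitrogen in a ring. Within the data shown here, nothing measured so far shows how this assay responds to a change at the amine nitrogen in the ring, so no direction can be derived from the data. With that in mind, the expected step from compound 2 to compound 3 is estimated as a 1.1-fold higher number from compound 2 to compound 3 (0.03 log units; within the scatter), that is, essentially none beyond the scatter. For compound 3 the estimated value is 3000 nM, with an expected range from 800 nM to 12000 nM.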

Compound 3, half-maximal effective concentration: 560 nM
Beside the measured number, compound 3's estimate is 5.4-fold (0.73 log units) above it; the measured number lies below the stated range.
By their numbers in this assay, from the lowest: compound 3; then compounds 1 and 2 (each within the scatter of the next).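

In this assay the amine nitrogen in the ring proves to be a place the read-out responds to: putting 3-(tert-butoxycarbonyl)propyl in place of oxan-4-yl gives a 5.1-fold lower number from compound 2 to compound 3 (0.70 log units; beyond the scatter) and this step lies beyond the scatter, whereas the earlier pair differed in two places at once and could say nothing about this position alone. The change is not a simple one, since the group that enters has 10 heavy atoms against 6, no ring, and 2 hydrogen-bond acceptors against 1, and a single step cannot separate these differences. Nothing available here accounts for the size or direction of the step.

From the compounds shown here alone, it remains open whether the whole chain matters or only part of it, and what a carboxylic acid in place of the tert-butoxycarbonyl part, a longer chain, or an amine on the chain would give. Going by these compounds, this step also rests on one pair carrying the chloro-substituted urea, so whether the same change would act alike on the urea of compound 1 remains unknown.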